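Alkyl extension on the benzylamine dioxane scaffold

The source may report more compounds than this note shows. Statements on the series, on what has been measured and on what is new or still open speak of the compounds shown alone.

Compound 2 `C[C@]1(c2ccccc2)OCC[C@H](CCNCc2ccccc2)O1` is the one numbered result: in an assay on brain for displacement of a labelled ligand from Sigma non-opioid intracellular receptor 1 (Cavia porcellus) (a higher number here means a weaker inhibitor, a lower number a stronger inhibitor), compound 2 gives 11 nM. Compound 1 `C[C@]1(c2ccccc2)OCC[C@H](CCN)O1` returns only the assay limit > 10000 nM in this assay. Compound 3 `CCC[C@]1(c2ccccc2)OCC[C@H](CCN)O1` likewise returns only the limit > 10000 nM in this assay. The benzyl step an at least 900-fold lower number from compound 1 to compound 2 (2.95 log units; beyond the scatter) is large, whereas a step that the two limits leave unreadable from compound 1 to compound 3 cannot be sized, both points resting on (the limit of > 10000 nM in this assay, at which 2 of the 3 values shown sit). Compound 4 `CC[C@]1(c2ccccc2)OCC[C@H](CCNCc2ccccc2)O1` differs from compound 2 by methyl in place of hydrogen on a saturated chain carbon bound to a saturated ring carbon. Among the measured compounds shown here, no measured step reads on this change with the benzyl present, and the only alkyl comparison is unreadable, so the expected step of a 1.4-fold higher number from compound 2 to compound 4 (0.13 log units; within the scatter) is within scatter. Compound 4 is estimated at 15 nM, range 4 nM to 60 nM.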

Compound 4, inhibition constant: 28 nM
Compound 4: middle estimate off by 1.9-fold (0.27 log units), on the low side; the range from low to high includes it.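

Among the compounds shown here, with the benzyl present, methyl to ethyl on a saturated chain carbon bound to a saturated ring carbon gives the first readable alkyl step, a 2.5-fold higher number from compound 2 to compound 4 (0.41 log units; beyond the scatter) in this assay. The step is modest, and compound 4 still gives 28 nM, so the ethyl group keeps the benzylamine in the low range of the values shown. The alkyl comparison without the benzyl cannot be read: the limit of > 10000 nM in this assay, at which 2 of the 4 values shown sit.

As far as these compounds go, whether the loss continues with chain length remains open, as a butyl chain at this place on the benzylamine would show. Also open, from the compounds shown here alone, is whether a phenethyl group on the amine nitrogen would keep the gain seen with benzyl.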